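This account rests on a few compounds, and the source may have more. Where it says the series, first, only, none or still open, it means among the compounds named here.

Compound 3 `Cn1cnc2c(N3CCCCC3)nc(-c3cccc(Cl)c3)nc21` gives 6.1% in an assay on cells for displacement of a labelled ligand from adenosine receptor A3 (Homo sapiens), read by scintillation counting and radioligand binding, with a stated time of 180 min, tested at 10 uM (a higher number here means more inhibition at the concentration tested (going by the name of the read-out), a lower number less inhibition), the lowest of the two numbers in the set. Compound 1 `Cn1cnc2c(N3CCCCC3)nc(-c3ccccc3O)nc21` gives 20% in this assay, and the step of a number 13.9 percentage points lower from compound 1 to compound 3 (beyond the scatter) is the nearest comparison. Compound 2 `Clc1cccc(-c2nc(N3CCCCC3)c3nc[nH]c3n2)c1` gives > 80% in this assay, which is a limit of the assay (the limit of > 80% in this assay, at which 1 of the 3 values shown sits). The step of a number at least 73.9 percentage points lower from compound 2 to compound 3 (beyond the scatter) concerns the methyl on the aromatic nitrogen and does not bear on the change to compound 4. Compound 4 `Cn1cnc2c(N3CCCCC3)nc(-c3ccccc3Cl)nc21` differs from compound 3 by 2-chlorophenyl in place of 3-chlorophenyl on an aromatic carbon. Of the measured steps only a number 13.9 percentage points lower from compound 1 to compound 3 (beyond the scatter) changes the group on this aromatic carbon, and it was modest. For compound 4 a step of similar or smaller size is expected, a number 5.9 percentage points higher from compound 3 to compound 4 (within the scatter). Compound 4 is expected to give 12% in this assay, with a range from 0% to 35%.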

Compound 4, a percentage reported as inhibition, at one concentration (the size of the read-out at that concentration, not a potency): 2.1%
Estimate against measurement, compound 4: 9.9 percentage points above; measured number inside the range.
By their numbers in this assay, from the lowest: compounds 4 and 3 (each within the scatter of the next); then compound 1. At a limit, above all of these: compound 2.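

The chlorine position on the phenyl ring makes no readable difference in this assay: a number 4 percentage points lower from compound 3 to compound 4 (within the scatter). Keeping the ring position fixed and swapping the group does register, with a number 17.9 percentage points lower from compound 1 to compound 4 (beyond the scatter), so 2-chlorophenyl and 2-hydroxyphenyl can be told apart. Nothing at hand bears on the reason for either step. Open, from the compounds shown here alone, is whether an amine or a carboxylic acid on this phenyl ring would raise the number. Going by these compounds, compound 2, with hydrogen on the aromatic nitrogen, sits at a limit, > 80%, and whether moving the chlorine reads differently on that core remains open.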